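This account rests on a few compounds, and the source may have more. Where it says the series, first, only, none or still open, it means among the compounds named here.

Of the compounds shown here, three of a shared core have so far been measured in an assay on cells with melanin-concentrating hormone receptor 1 (Homo sapiens) as the target, read by radioligand binding; a lower number here means a stronger inhibitor, a higher number a weaker inhibitor. Compound 1 `Nc1ccc2cccc(OC3CCCCCC3)c2n1` gives 137 nM. Compound 2 `Nc1ccc2cccc(OCC3CCCC3)c2n1` gives 53 nM, the lower of the two numbers, and its gap to compound 1 lies beyond the usual scatter. Compound 3 `CC(CC(C)(C)C)Oc1cccc2ccc(N(C)C)nc12` reaches only a limit of this assay, > 2000 nM, as noted in the limit of > 2000 nM in this assay, at which 1 of the 3 values shown sits. Compound 4 `Nc1ccc2cccc(OCCC3CC3)c2n1` has not yet been measured. It differs from compound 2 by cyclopropylmethyl in place of cyclopentyl on a saturated chain carbon bound to an oxygen on an aromatic ring. Within the data shown here, no single step of this kind has been measured, so only a small step from compound 2 to compound 4 in this assay is expected, at most a modest weakening and possibly none beyond the scatter. Compound 4 is therefore estimated at 85 nM, with a range from 30 nM to 250 nM. This estimate means an expected step of a 1.6-fold higher number from compound 2 to compound 4 (0.21 log units; within the scatter).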

Compound 4, half-maximal inhibitory concentration: 492 nM
The estimate for compound 4 lay 5.8-fold (0.76 log units) below the measured number; measured number above the stated range.
By their numbers in this assay, from the lowest: compound 2; then compound 1; then compound 4. At a limit, above all of these: compound 3.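

Cyclopropylmethyl in place of cyclopentyl on a saturated chain carbon bound to an oxygen on an aromatic ring gives a 9.3-fold higher number from compound 2 to compound 4 (0.97 log units; beyond the scatter) in this assay, a step that is larger than a change of this kind might suggest. Among these compounds, this is the first single change read at this place, and it shows that the number in this assay responds clearly to the group carried there. Nothing shown gives a cause for this step. Open remains how a longer chain, an amine or a carboxylic acid would read at this place.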